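Cytotoxicity of compounds 1 and 2 and the step to compound 3

This account rests on a few compounds, and the source may have more. Where it says the series, first, only, none or still open, it means among the compounds named here.

Measured in an ADME assay on MDCK cells (Canis lupus familiaris) for cytotoxicity, read by MTT assay, with a stated time of 48 h (on this read-out lower numbers stand for higher toxicity in this test and higher numbers for lower toxicity in this test), so far
Compound 1 (`Cc1cccc(NC(=O)CSc2nc(-c3ccccc3)cc(-c3ccccc3)c2C#N)c1`) gives > 250000 nM
Compound 2 (`CC[C@H](C)[C@H](NC(=O)CSc1nc(-c2ccccc2)cc(-c2ccc(C)cc2)c1C#N)C(=O)OC`) gives > 250000 nM

Compound 2 gives > 250000 nM as a limit of the assay and not as a number. Compound 1 gives > 250000 nM and this too is only a limit. Neither compound therefore has an exact value, and the whole measured picture is the limit of > 250000 nM in this assay, at which 2 of the 2 values shown sit, with nothing yet resolved beneath it.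

Compound 3 (`Cc1ccc(-c2cc(-c3ccccc3)nc(SCC(N)=O)c2C#N)cc1`) carries hydrogen in place of 1-(methoxycarbonyl)-2-methylbutyl on an amide-type nitrogen and otherwise matches compound 2. Going by the values given here, no measured pair of compounds differs in one place, so no earlier step can serve as a guide. The expectation rests only on compound 2 at > 250000 nM in this assay and on the shared limit of the two measured compounds. No change beyond the usual scatter, in either direction, is expected, and the expected step is a step that the limit leaves unreadable from compound 2 to compound 3 on that reading. For compound 3 the estimate is 300000 nM with an expected range from 120000 nM to 600000 nM and a good chance that the outcome is again only a limit.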

Compound 3, half-maximal cytotoxic concentration: > 250000 nM
Compound 3: only a limit was reported; the forecaster's own chance of this, stated with the estimate: 75%; the middle value is on the limit's open side.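

In this assay compound 3 gives > 250000 nM, which is a limit of the assay and not a number. Compound 2 gives > 250000 nM, also only a limit, so no step can be read between compound 2 and compound 3. The compounds shown leave open whether exchanging 1-(methoxycarbonyl)-2-methylbutyl for hydrogen changes the read-out at all, and where any exact value would lie, with the whole picture still resting on one point: the limit of > 250000 nM in this assay, at which 3 of the 3 values shown sit.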